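A few compounds are considered here, and "the series" means these few. Any claim that something is new, unique, unknown or untested is made for them only; others in the source may bear on it.

Measured so far:
compound 1, `Cc1nsc2c1ncn2[C@H]1C[C@H](O)[C@@H](CO)O1` — > 100000 nM
compound 2, `CSc1nc2c(C)nsc2n1[C@H]1C[C@H](O)[C@@H](CO)O1` — > 100000 nM
compound 3, `Cc1nsc2c1ncn2[C@@H]1O[C@H](CO)[C@@H](O)[C@@H]1O` — > 100000 nM

In a functional assay on L1210 cells (Mus musculus) for antiproliferative activity (on this read-out lower numbers stand for stronger inhibition and higher numbers for weaker inhibition), compound 1 gives only a limit of the assay, > 100000 nM. Compound 2 likewise reaches only a limit there, > 100000 nM. Compound 3 too sits at a limit, > 100000 nM. The core of compound 3 differs from that of compound 1 by hydroxy in place of hydrogen on a saturated ring carbon. Compound 2 arises from compound 1 by methylsulfanyl in place of hydrogen on an aromatic carbon, and that step, a step that the two limits leave unreadable from compound 1 to compound 2, cannot be sized, since (the limit of > 100000 nM in this assay, at which 3 of the 3 values shown sit).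

Compound 4, `CSc1nc2c(C)nsc2n1[C@@H]1O[C@H](CO)[C@@H](O)[C@@H]1O`, not yet measured, arises from compound 3 by methylsulfanyl in place of hydrogen on an aromatic carbon, the same kind of change, differing only in that the neighbouring ring atom bears a group of 9 rather than 8 heavy atoms. Because the limit of > 100000 nM in this assay, at which 3 of the 3 values shown sit, holds for all three, compound 4 is expected to stay at that limit as well, a step of about a number no higher from compound 3 to compound 4 (the limit leaves the size open). The estimate for compound 4 in this assay is 100000 nM, between 20000 nM and 500000 nM.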

Compound 4, half-maximal inhibitory concentration: > 100000 nM
Compound 4: a limit, no number (the forecaster's own chance of this, stated with the estimate: 85%); the middle value lies on the limit itself.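

In this assay compound 4 also stands at a limit, > 100000 nM. Within the data shown here, no step to it from compound 3 or compound 2 can be read: the limit of > 100000 nM in this assay, at which 4 of the 4 values shown sit. Whether methylsulfanyl or hydroxy changes the activity of these compounds at all stays open.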